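The compounds below may be only part of what the source reports. "The series", "measured", "known", "first", "only" and "open" are said of these compounds alone.

Measured so far in a functional assay on MCF7 cells (Homo sapiens) for inhibition, read by MTT assay, with a stated time of 72 h; a lower number here means a stronger inhibitor, a higher number a weaker inhibitor:

- compound 1, `Cc1ccc(Nc2nc(SCc3cn(CC(=O)NC(=O)Nc4ccccn4)nn3)nc(-c3ccc(C(C)C)cc3)c2C#N)cc1`: only a limit, > 64000 nM
- compound 2, `Cc1ccc(Nc2nc(SCc3cn(CC(=O)NC(=O)Nc4ccccn4)nn3)nc(-c3ccc(C)cc3)c2C#N)cc1`: 39600 nM
- compound 3, `CC(C)c1ccc(Nc2nc(SCc3cn(CC(=O)NC(=O)Nc4ccccn4)nn3)nc(-c3ccc(Cl)cc3)c2C#N)cc1`: 39900 nM

Compound 3 and compound 2 give numbers that lie within the scatter of each other, so neither can be placed above the other. Compound 1 gives no number at all; it sits at the limit of > 64000 nM in this assay, at which 1 of the 3 values shown sits.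

Compound 4, `Cc1ccc(Nc2nc(SCc3cn(CC(=O)NC(=O)Nc4ccccn4)nn3)nc(-c3ccc(Cl)cc3)c2C#N)cc1`, is not yet measured. It differs from compound 3 in one place: methyl in place of isopropyl on an aromatic carbon.

The same change has been measured once, from compound 1 to compound 2: an at least 1.6-fold lower number from compound 1 to compound 2 (0.20 log units; that floor lies within the scatter). That step starts from a limit, and its floor is within the scatter, so it shows at most a small move towards a lower number and is consistent with no real change. Among the compounds with values here, for compound 4 the same is expected: no step in this assay beyond the scatter, with a slight lean towards a lower number. The step from compound 3 to compound 4 is therefore estimated at a 1.3-fold lower number from compound 3 to compound 4 (0.12 log units; within the scatter). Compound 4 is expected to give 30000 nM, in the range 12000 nM to 75000 nM.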

Compound 4, half-maximal inhibitory concentration: 27000 nM
The estimate for compound 4 lay 1.1-fold (0.05 log units) above the measured number, within the range that was stated.
By their numbers in this assay, from the lowest: compounds 4, 2 and 3 (each within the scatter of the next). At a limit, above all of these: compound 1.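

Methyl in place of isopropyl, here as (4-isopropylphenyl)amino to (4-methylphenyl)amino, now has a step in this assay with a number at both ends, a 1.5-fold lower number from compound 3 to compound 4 (0.17 log units; within the scatter), and it can be set against the earlier reading of the same change: the same change on two cores in this assay, an at least 1.6-fold lower number (0.20 log units; that floor lies within the scatter) from compound 1 to compound 2 and a 1.5-fold lower number (0.17 log units; within the scatter) from compound 3 to compound 4; the limit leaves it open whether they differ. Chloro in place of methyl on the 4-substituted phenyl ring gives no step beyond the scatter either: a 1.5-fold lower number from compound 2 to compound 4 (0.17 log units; within the scatter). Chloro in place of isopropyl is the only new step beyond the scatter, and it starts from a limit: an at least 2.3-fold lower number from compound 1 to compound 4 (0.37 log units; beyond the scatter).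

The compounds shown carry only isopropyl, methyl or chloro at these places, so the effect of a methoxy group, an amine or a carboxylic acid there remains open. Also open, as far as these compounds go, is how far compound 1 truly lies from the others, since its value is a limit.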